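This account rests on a few compounds, and the source may have more. Where it says the series, first, only, none or still open, it means among the compounds named here.

Of the compounds shown here, three sharing one core have been measured so far in a functional assay on MCF7 cells (Homo sapiens) for inhibition; on this read-out higher numbers stand for weaker inhibition and lower numbers for stronger inhibition. Compound 1 (`CCn1c(=O)/c(=C2\Sc3ccccc3N2C)s/c1=C\c1ccncc1Nc1ccccc1F`) gives 330 nM there. Compound 2 (`CCn1c(=O)/c(=C2\Sc3ccccc3N2C)s/c1=C\c1ccncc1Nc1ccccc1C`) gives 990 nM and compound 3 (`CCn1c(=O)/c(=C2\Sc3ccc(OC)cc3N2C)s/c1=C\c1ccncc1Nc1ccccc1C`) gives 420 nM on the same scale. Compound 2 thus has the highest number of the three, which makes it the weakest inhibitor of this small set, and its gaps to both others lie beyond the usual scatter.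

Compound 4 (`CCn1c(=O)/c(=C2\Sc3ccccc3N2C)s/c1=C\c1ccncc1Nc1cc(F)ccc1F`) has not yet been measured. It differs from compound 2 in one place (2,5-difluorophenyl in place of 2-methylphenyl on a nitrogen on an aromatic ring), with 2,5-difluorophenyl in place of 2-methylphenyl on a nitrogen on an aromatic ring. The measured step that bears most directly on this is a 3.0-fold higher number from compound 1 to compound 2 (0.48 log units; beyond the scatter) when methyl takes the place of fluoro on an aromatic carbon. Compound 4 also swaps that methyl for fluoro, so this modest step, read backwards, points to a lower number. Going by the values given here, the second fluoro of compound 4 has no measured counterpart. The other step, a 2.4-fold lower number from compound 2 to compound 3 (0.37 log units; beyond the scatter) when methoxy takes the place of hydrogen on an aromatic carbon, concerns a different part of the molecule and offers little guidance.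

With compound 1 at 330 nM as the nearest guide, a modest fall is expected rather than a large one. The step expected in this assay is a 3.1-fold lower number from compound 2 to compound 4 (0.49 log units; beyond the scatter) by this estimate. Compound 4 is expected at 320 nM with a range from 130 nM to 800 nM as the estimate.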

Compound 4, half-maximal inhibitory concentration: 1500 nM
The estimate for compound 4 lay 4.7-fold (0.67 log units) below the measured number; measured number above the stated range.
By their numbers in this assay, from the lowest: compounds 1 and 3 (each within the scatter of the next); then compounds 2 and 4 (each within the scatter of the next).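

In this assay, putting 2,5-difluorophenyl in place of 2-methylphenyl on the nitrogen leaves the number within the usual scatter (a 1.5-fold higher number from compound 2 to compound 4 (0.18 log units; within the scatter)), so this change does not separate compound 2 from compound 4. The comparison with compound 1 is the more telling one: a single extra fluoro in place of hydrogen on the same phenyl ring gives a modest rise (a 4.5-fold higher number from compound 1 to compound 4 (0.66 log units; beyond the scatter)), which shows that the number at this position depends on more than swapping methyl for fluoro, and that having one fluoro on the ring does not ensure a lower number once a second is added. Nothing available explains why this one added fluoro matters.

The compounds shown leave open whether a chloro or a nitrile on this phenyl ring would behave like the single fluoro of compound 1 or like the two fluoro groups of compound 4. On these data alone, it also remains open whether the methoxy step seen elsewhere on the molecule (a 2.4-fold lower number from compound 2 to compound 3 (0.37 log units; beyond the scatter)) would appear in the same way if methoxy were added to compound 1 or compound 4.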